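Shifting the Methoxy Group from Compound 1 to Compound 4

This account rests on a few compounds, and the source may have more. Where it says the series, first, only, none or still open, it means among the compounds named here.

Compound 1 `COc1ccc(-c2cn(C/C=C3\OC(=O)C(OCc4ccccc4)=C3OCc3ccccc3)nn2)cc1`: > 100000 nM
Compound 2 `Cc1ccc(-c2cn(C[C@H](O)[C@H]3OC(=O)C(OCc4ccccc4)=C3OCc3ccccc3)nn2)cc1`: 25500 nM
Compound 3 `CC(C)(C)OC(=O)N1CCN(C(=S)SCc2cn(C[C@H](O)[C@H]3OC(=O)C(OCc4ccccc4)=C3OCc3ccccc3)nn2)CC1`: > 100000 nM

In a functional assay on HeLa cells (Homo sapiens) for antiproliferative activity, read by MTT assay, with a stated time of 72 h (on this read-out higher numbers stand for weaker inhibition and lower numbers for stronger inhibition), compound 1 returns only a limit, > 100000 nM, and no number. Compound 3 likewise returns only a limit, > 100000 nM. Compound 2 gives a number, 25500 nM. Compound 1 therefore sits at the limit of > 100000 nM in this assay, at which 2 of the 3 values shown sit, and no measured step exists between any pair of these compounds.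

Compound 4 `COc1ccccc1-c1cn(C/C=C2\OC(=O)C(OCc3ccccc3)=C2OCc2ccccc2)nn1` keeps the core of compound 1 and differs only in the change (2-methoxyphenyl in place of 4-methoxyphenyl on an aromatic carbon). Nothing among the three measured compounds bears on this change, so compound 4 is expected to show no step beyond the scatter, with an expected step that the limit leaves unreadable from compound 1 to compound 4. Compound 4 is estimated at 120000 nM, within 40000 nM to 400000 nM, most likely again only a limit.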

Compound 4, half-maximal inhibitory concentration: > 100000 nM
Compound 4 was reported as a limit; the forecaster's own chance of this, stated with the estimate: 80%; the middle value does not contradict the limit.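

Compound 4 returns only a limit, > 100000 nM. Within the data shown here, compound 1 also stands at a limit, so no step from one to the other can be read. As far as these compounds go, whether 2-methoxyphenyl in place of 4-methoxyphenyl alters activity at all remains open.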